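From a ring to an open chain in compound 3

This account rests on a few compounds, and the source may have more. Where it says the series, first, only, none or still open, it means among the compounds named here.

In an ADME assay on microsomes from liver (Mus musculus) for metabolic stability (a lower number here means that the compound disappears faster, a higher number that the compound lasts longer), compound 1 (`Cc1nc(C(c2ccc(-c3ccc4cccc(F)c4c3)[nH]c2=O)C(C)C)[nH]c1C`) gives 0.0817 h and compound 2 (`CC(C)C(c1cnc(N)s1)c1ccc(-c2ccc3cccc(F)c3c2)[nH]c1=O`) gives 0.08 h as its half-life. For the measured compounds named here, compound 2 therefore stands level with the only other measured number, and the pair cannot be told apart. Going by the values given here, the one measured step is a 1.0-fold lower number from compound 1 to compound 2 (0.01 log units; within the scatter) and it is the only evidence on this place in the molecule. Compound 3 (`CC(C)C(CC(N)=O)c1ccc(-c2ccc3cccc(F)c3c2)[nH]c1=O`) has not yet been measured. Its change from compound 2 is carbamoylmethyl in place of 2-amino-1,3-thiazol-5-yl on a saturated chain carbon bound to an aromatic carbon and a saturated chain carbon and it falls at that same place. The measured step exchanged one ring for another, whereas here the ring leaves and carbamoylmethyl, which has no ring, enters, so the evidence reaches only part of the way. Among the compounds with values here, no measured compound has an open chain here. Within the data shown here, with a 1.0-fold lower number from compound 1 to compound 2 (0.01 log units; within the scatter) as the sole guide, no shift beyond the scatter is expected in this assay for this change. The expected step, an estimate, is a 1.3-fold higher number from compound 2 to compound 3 (0.10 log units; within the scatter) and stays within the scatter. For compound 3 the estimated half-life is 0.1 h with a range of 0.05 h to 0.25 h for now.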

Compound 3, half-life: < 0.0667 h
Compound 3 ended at the assay's limit; the forecaster's own chance of this, stated with the estimate: 10%; middle value at least 1.4-fold (0.17 log units) from the limit.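

In this assay, for the compounds shown here, compound 3 reads < 0.0667 h, which is a limit of the assay and not a number, and it is the first reading at this place, on a saturated chain carbon bound to an aromatic carbon and a saturated chain carbon, for a group with no ring. Its two steps, an at least 1.1-fold lower number from compound 2 to compound 3 (0.07 log units; that floor lies within the scatter) and an at least 1.2-fold lower number from compound 1 to compound 3 (0.08 log units; that floor lies within the scatter), are floors only, so the open chain is neither shown to stand apart from the two rings nor shown to stand level with them. Where the earlier pair gave a step of known size, the true size of these steps stays unknown, because the reading of compound 3 rests at the end of the assay's range: the limit of < 0.0667 h in this assay, at which 1 of the 3 values shown sits.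

The compounds shown leave open whether a difference, if there is one, goes with the loss of the ring or with the carbamoylmethyl group itself. A plain alkyl chain, a longer chain ending in the same amide, or a carboxylic acid or an amine at the end of the chain would bear on that question at this place.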